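The source may hold more compounds than are shown below. What is called first, only, known or untested is meant among the compounds shown, and "the series" means these compounds.

Three compounds have numbers in a functional assay on MV4-11 cells (Homo sapiens) for inhibition, read by resazurin assay, with a stated time of 72 h; on this read-out lower numbers stand for stronger inhibition of growth and higher numbers for weaker inhibition of growth: compound 1 (`CCn1cc(-c2ccnc(Nc3ccc(OC)cc3OC)n2)c2ccccc21`), compound 2 (`COc1ccc(Nc2nccc(-c3c[nH]c4ccccc34)n2)c(OC(F)F)c1`) and compound 3 (`COCCSc1nc(C)c(-c2ccnc(Nc3ccc(OC)cc3OC)n2)s1`). Compound 2 gives 4770 nM, which lies within the scatter of compound 1 at 3590 nM. Compound 3 gives 810 nM, and compound 2 stands beyond the scatter above it, so compound 2 belongs to the upper pair of the three.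

The next compound, compound 4 (`COc1ccc(Nc2nccc(-c3c[nH]c4ccccc34)n2)c(OC)c1`), differs from compound 2 in one place: methyl in place of difluoromethyl on an oxygen on an aromatic ring. This puts methyl in place of difluoromethyl on an oxygen on an aromatic ring, turning difluoromethoxy into methoxy. Among the compounds with values here, no measured pair isolates this change in this assay, so the evidence is indirect. Compound 1 also carries methoxy, on a different core, and gives 3590 nM. Compound 3 carries methoxy too, again on a different core, and gives 810 nM. These two values do not agree, so they offer only a loose guide. The closer match is compound 1, whose value sits within the scatter of compound 2, and so no change beyond the scatter is expected, with at most a slight drift toward a lower number. The estimated step is a 1.4-fold lower number from compound 2 to compound 4 (0.16 log units; within the scatter). For compound 4 the expected value is 3300 nM, with an estimated range from 1200 nM to 8000 nM.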

Compound 4, concentration for 50% growth inhibition: 600 nM
Compound 4: the middle estimate sits 5.5-fold (0.74 log units) above what was measured, outside the stated range (below it).
By their numbers in this assay, from the lowest: compounds 4 and 3 (each within the scatter of the next); then compounds 1 and 2 (each within the scatter of the next).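

In this assay, methyl in place of difluoromethyl on an oxygen on an aromatic ring gives an 8.0-fold lower number from compound 2 to compound 4 (0.90 log units; beyond the scatter), so this first direct reading of the change shows that the group on this oxygen matters on the shared core, which the indirect comparison across different cores could not establish. Compound 4 also provides a second single-place comparison at a different site: hydrogen in place of ethyl on an aromatic nitrogen gives a 6.0-fold lower number from compound 1 to compound 4 (0.78 log units; beyond the scatter), showing that with methoxy on the aromatic ring, the group on that nitrogen matters as well. Nothing given here explains either step.

The compounds shown leave open how other groups on the same oxygen would read, such as ethyl, trifluoromethyl or a longer chain ending in an amine, and whether a hydrogen there, giving a free hydroxyl, would follow methoxy or difluoromethoxy. They also leave open how methyl or a longer chain on the aromatic nitrogen would compare with hydrogen and ethyl, and whether the difluoromethoxy-to-methoxy step would keep its size on the core of compound 1 or compound 3.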